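Methyl to Methoxy on a Five-Ring Fused Core

The source may hold more compounds than are shown below. What is called first, only, known or untested is meant among the compounds shown, and "the series" means these compounds.

Compound 1 `Cc1cccc2cc3c(nc12)-c1nc2ccccc2n1C3` and compound 2 `Cc1ccc2cc3c(nc2c1)-c1nc2ccccc2n1C3` are built from the same atoms joined differently; how their two cores differ is not broken down here. Compound 3 `COc1cccc2cc3c(nc12)-c1nc2ccccc2n1C3` arises from compound 1 by methoxy in place of methyl on an aromatic carbon. In a functional assay on MDA-MB-231 cells (Homo sapiens) for cytotoxicity, read by MTT assay, with a stated time of 72 h (on this read-out lower numbers stand for stronger inhibition and higher numbers for weaker inhibition), compound 1 gives > 100000 nM, a limit of the assay. Compound 2 likewise gives only a limit, > 100000 nM. Compound 3 also sits at a limit, > 100000 nM. Hence a step that the two limits leave unreadable from compound 1 to compound 3, since the limit of > 100000 nM in this assay, at which 3 of the 3 values shown sit, covers all three values. Compound 4 `COc1ccc2cc3c(nc2c1)-c1nc2ccccc2n1C3`, still unmeasured, carries the same kind of change, (methoxy in place of methyl on an aromatic carbon), the place being meta to a fused ring and para to a fused ring rather than ortho and meta. For compound 4 the expected result is 150000 nM. That expectation rests on compound 2, whose value > 100000 nM is a limit. The expected step is a step that the limit leaves unreadable from compound 2 to compound 4.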

Compound 4, half-maximal inhibitory concentration: > 100000 nM
Compound 4 ended at the assay's limit (the forecaster's own chance of this, stated with the estimate: 85%); the middle value lies beyond the limit too.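

Compound 2 and compound 4 both sit at a limit, so no step can be read between them: the limit of > 100000 nM in this assay, at which 4 of the 4 values shown sit.

Going by these compounds, whether methoxy or methyl gives the stronger inhibition, and at what concentration any of the four compounds reaches half-maximal inhibition, stays open.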